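A second methyl on the 4-methylphenyl group

This account rests on a few compounds, and the source may have more. Where it says the series, first, only, none or still open, it means among the compounds named here.

Values from an ADME assay on microsomes from liver (Rattus norvegicus) for metabolic stability, read by LC-MS, using NADPH, at 37 degrees C (a higher number here means that the compound lasts longer, a lower number that the compound disappears faster), given as half-life:
- compound 1 (`Cc1oc(-c2c(F)cccc2F)nc1CN1CCC(C(=O)NCCCN2C[C@H](C)C[C@H](C)C2)CC1`) gives 0.35 h
- compound 2 (`Cc1cccc(-c2nc(CN3CCC(C(=O)NCCCN4C[C@H](C)C[C@H](C)C4)CC3)c(C)o2)c1`) gives > 0.5 h as a limit
- compound 3 (`Cc1ccc(-c2nc(CN3CCC(C(=O)NCCCN4C[C@H](C)C[C@H](C)C4)CC3)c(C)o2)cc1`) gives > 0.5 h as a limit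

Compound 3 stands at > 0.5 h in this assay, which is a limit of the assay and not a number. The same limit holds for most of the series, as the limit of > 0.5 h in this assay, at which 2 of the 3 values shown sit, shows.

Compound 4 (`Cc1ccc(-c2nc(CN3CCC(C(=O)NCCCN4C[C@H](C)C[C@H](C)C4)CC3)c(C)o2)c(C)c1`) differs from compound 3 by methyl in place of hydrogen on an aromatic carbon, ortho to a large group and meta to a methyl group, so that 4-methylphenyl becomes 2,4-dimethylphenyl (methyl in place of hydrogen on an aromatic carbon).

The measured steps that touch this group are an at least 1.4-fold higher number from compound 1 to compound 2 (0.15 log units; that floor lies within the scatter) and an at least 1.4-fold higher number from compound 1 to compound 3 (0.15 log units; that floor lies within the scatter), and neither floor passes the scatter. The third is a step that the two limits leave unreadable from compound 2 to compound 3 and gives no size. Within the data shown here, no measured step adds a methyl to a ring that already carries one, so no step beyond the scatter is expected, in either direction. The expected change is a number no higher from compound 3 to compound 4 (the limit leaves the size open) in this series. Compound 4 may well be reported only as a limit again. For compound 4 the estimated value is 0.5 h, with an expected range from 0.3 h to 1 h in this assay.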

Compound 4, half-life: > 0.5 h
Compound 4: a limit, no number; the forecaster's own chance of this, stated with the estimate: 55%; the middle value sits exactly at the limit.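

In this assay compound 4 gives > 0.5 h, which is a limit of the assay and not a number. A methyl ortho to a large group, added to a ring that already carries a methyl group, thus leaves the half-life at the same limit, so the steps that link compound 4 to compound 2 and compound 3 cannot be read, and the limit now covers most of the values shown: the limit of > 0.5 h in this assay, at which 3 of the 4 values shown sit. The one step that can be read is an at least 1.4-fold higher number from compound 1 to compound 4 (0.15 log units; that floor lies within the scatter), so this position is the first shown to hold a methyl with the value still reported as a limit, though that floor alone does not set the 2,4-dimethylphenyl group apart from the 2,6-difluorophenyl group.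

As far as these compounds go, how far compound 3 and compound 4 each lie past the limit remains open, so the size and even the direction of the effect of the added methyl are unknown. Also open, from the compounds shown here alone, is how the half-life would respond to a chlorine atom or a methoxy group at this same position.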